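The source may hold more compounds than are shown below. What is called first, only, known or untested is meant among the compounds shown, and "the series" means these compounds.

Within the data shown here, compound 1 `COc1c(NS(=O)(=O)c2ccc(F)cc2)cc(-c2ccc3nc(NC(=O)C4CC4)sc3n2)cc1C(N)=O` is the only compound here with a number: in a functional assay on MCF7 cells (Homo sapiens) for antiproliferative activity, read by MTT assay, with a stated time of 72 h (a lower number here means a stronger inhibitor, a higher number a weaker inhibitor), compound 1 gives 22100 nM. Compound 2 `NC(=O)c1cc(NS(=O)(=O)c2ccc(F)cc2)cc(-c2ccc3nc(NC(=O)C4CC4)sc3c2)c1` shares much of its build, yet in this assay compound 2 gives "not determined" (no result reported), so it stands on no number at all. Compound 3 `NC(=O)c1cc(-c2ccc3nc(NC(=O)C4CC4)sc3c2)cc(NS(=O)(=O)c2ccc(F)cc2)c1Cl` differs from compound 2 by a single change, (chloro in place of hydrogen on an aromatic carbon). Among the measured compounds shown here, with no measured step to lean on, the size and direction of this change in this assay cannot be told; anything beyond the scatter is as likely as none. Compound 3 is expected to show about 10000 nM, estimated between 1500 nM and 60000 nM.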

Compound 3, half-maximal inhibitory concentration: > 50000 nM
Compound 3 ended at the assay's limit (the forecaster's own chance of this, stated with the estimate: 25%); at least 5.0-fold (0.69 log units) between middle value and limit.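

No step can be read from compound 2 to compound 3, since compound 2 has no reported result. Compound 3 stands only at a limit, not a number. Going by these compounds, whether chloro in place of hydrogen changes the result in this assay stays open.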